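The source may hold more compounds than are shown below. What is called first, only, known or untested is meant among the compounds shown, and "the series" means these compounds.

Measured so far:
Compound 1 `CCOc1ccc2nc(-c3c(Cl)nc(N)nc3N[C@@H]3C[C@H](CO)[C@@H](O)[C@H]3O)sc2c1` — > 25000 nM
Compound 2 `CN(C)c1ccc2sc(-c3c(Cl)nc(N)nc3N[C@@H]3C[C@H](CO)[C@@H](O)[C@H]3O)nc2c1` — 25000 nM
Compound 3 `CCNc1nc(C)c(-c2nc3ccccc3s2)c(N[C@@H]2C[C@H](CO)[C@@H](O)[C@H]2O)n1` — 12000 nM

In an ADME assay on cells (Homo sapiens) for cytotoxicity, read by polymerase chain reaction, with a stated time of 3 days (a higher number here means that more compound is tolerated, a lower number that less compound is tolerated), compound 1 reaches only a limit, and that limit is the limit of > 25000 nM in this assay, at which 1 of the 3 values shown sits. Among the two actual numbers, compound 3 gives the lowest; the nearest number, that of compound 2, is higher by a gap that lies beyond the usual scatter.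

Compound 4 `Cc1nc(NCC2CC2)nc(N[C@@H]2C[C@H](CO)[C@@H](O)[C@H]2O)c1-c1nc2ccccc2s1` has not yet been measured in this assay. It differs from compound 3 in one place: cyclopropyl in place of methyl on a saturated chain carbon bound to a nitrogen on an aromatic ring. Within the data shown here, no step between two measured compounds matches this change, so the expectation rests on compound 3 alone. A change of this kind, which adds three carbons in a small ring on the chain carbon bound to the ring nitrogen, is not expected to move a cytotoxicity read-out by much, so the step of no change at the digits printed from compound 3 to compound 4 (within the scatter) is estimated to stay within the scatter, with no clear direction. Compound 4 is therefore expected to give about 12000 nM in this assay, within a range from 5000 nM to 28000 nM.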

Compound 4, half-maximal cytotoxic concentration: 8000 nM
For compound 4 the middle estimate is 1.5-fold (0.18 log units) above the measured one, within the range that was stated.
By their numbers in this assay, from the lowest: compounds 4 and 3 (each within the scatter of the next); then compound 2.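

In this assay, among these compounds, the exchange of methyl for cyclopropyl on a saturated chain carbon bound to a nitrogen on an aromatic ring gives the first step that can be read at this position, a 1.5-fold lower number from compound 3 to compound 4 (0.18 log units; within the scatter). Ethylamino and (cyclopropylmethyl)amino therefore cannot be told apart in this read-out, so this position tolerates the added small carbon ring without a change beyond the scatter. Nothing measured here accounts for this result.

The compounds shown leave open whether a longer chain, a chain ending in an amine or a chain ending in a carboxylic acid on this nitrogen would also stay within the scatter of compound 3. They also leave open whether the same exchange would behave alike in the setting of compound 1 or compound 2.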